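The compounds below may be only part of what the source reports. "The series", "measured", "known", "first", "only" and "open" are said of these compounds alone.

Among the compounds with values here, compound 3, `O=C(Nc1cccc(-c2ccccc2Cl)c1)C(Cl)Cl`, is the only member of this set with a numbered value: in a functional assay on A549 cells (Homo sapiens) for cytotoxicity, read by MTT assay, with a stated time of 68 h (on this read-out lower numbers stand for stronger inhibition and higher numbers for weaker inhibition), compound 3 gives 22600 nM. Compound 1, `O=C(Nc1cccc(-c2nccs2)c1)C(Cl)Cl`, reaches only the limit of the assay, with > 50000 nM. Compound 2, `O=C(Nc1cccc(-c2ccc(-c3ccccc3)cc2)c1)C(Cl)Cl`, likewise stops at a limit, > 50000 nM. Both therefore sit at the limit of > 50000 nM in this assay, at which 2 of the 3 values shown sit. Compound 4, `O=C(Nc1cccc(-c2ccccc2)c1)C(Cl)Cl`, has not yet been measured; it differs from compound 3 by hydrogen in place of chloro on an aromatic carbon. Within the data shown here, no measured pair isolates this change, so the step from compound 3 to compound 4 can only be expected: a modest move toward weaker inhibition, near the edge of the scatter, a 1.8-fold higher number from compound 3 to compound 4 (0.25 log units; within the scatter). Compound 4 is accordingly estimated at 40000 nM, within 15000 nM to 110000 nM, with a fair chance that this assay again reports only a limit.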

Compound 4, half-maximal inhibitory concentration: 8900 nM
The estimate for compound 4 lay 4.5-fold (0.65 log units) above the measured number; the measured number lies below the stated range.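

At this aromatic carbon, ortho to a large group, hydrogen in place of chloro gives a 2.5-fold lower number from compound 3 to compound 4 (0.40 log units; beyond the scatter) in this assay, so chloro there is not required for the activity seen. Hydrogen in place of phenyl on an aromatic carbon gives an at least 5.6-fold lower number from compound 2 to compound 4 (0.74 log units; beyond the scatter), and phenyl in place of 1,3-thiazol-2-yl on an aromatic carbon gives an at least 5.6-fold lower number from compound 1 to compound 4 (0.74 log units; beyond the scatter). Both of these steps are bounds only, since compound 1 and compound 2 stop at a limit: the limit of > 50000 nM in this assay, at which 2 of the 4 values shown sit. The compounds shown leave open how a fluorine atom, a methoxy group or an amine at this carbon would compare with hydrogen and chloro.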